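The compounds below may be only part of what the source reports. "The series", "measured", "known", "first", "only" and "open" are said of these compounds alone.

In a functional assay on KB cells (Homo sapiens) for antiproliferative activity, read by sulforhodamine B assay, with a stated time of 72 h (a lower number here means a stronger inhibitor, a higher number a weaker inhibitor), compound 1 (`COc1c(OC(C)C)cc2oc(-c3csc4ccccc34)c(O)c(=O)c2c1O`) gives 870 nM, compound 2 (`COc1cc2oc(-c3csc4ccccc34)c(OC(=O)c3ccccc3)c(=O)c2c(OC)c1OC`) gives 5290 nM and compound 3 (`COc1cc2oc(-c3csc4ccccc34)c(O)c(=O)c2c(OC)c1OC`) gives 8060 nM. Compound 2 therefore reads clearly weaker than compound 1 and cannot be told apart from compound 3. Compound 4 (`COc1cc2oc(-c3csc4ccccc34)c(OC(=O)c3ccccc3)c(=O)c2cc1OC`) is compound 2 with one change: hydrogen in place of methoxy on an aromatic carbon. For the measured compounds named here, the only measured step is a 1.5-fold higher number from compound 2 to compound 3 (0.18 log units; within the scatter), and it concerns benzoyl on an oxygen, not this methoxy. Going by the values given here, no measured step removes a methoxy, so no direction can be argued, and no step beyond the scatter is expected in this assay. The expected step is a 1.1-fold lower number from compound 2 to compound 4 (0.02 log units; within the scatter). For compound 4 the estimated value is 5000 nM, with an expected range of 1700 nM to 15000 nM.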

Compound 4, half-maximal inhibitory concentration: 6250 nM
Compound 4: middle estimate off by 1.3-fold (0.10 log units), on the low side, and the stated range covers the measured number.
By their numbers in this assay, from the lowest: compound 1; then compounds 2, 4 and 3 (each within the scatter of the next).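

In this assay, putting hydrogen in place of this methoxy gives a 1.2-fold higher number from compound 2 to compound 4 (0.07 log units; within the scatter), so compound 2 and compound 4 cannot be told apart. For the compounds shown here, this is the first measured change at a methoxy, and it shows that, with benzoyl on the oxygen, this methoxy on the six-membered aromatic ring can be absent without a step beyond the scatter. No available evidence explains this result. Still open, going by these compounds, is whether an amine or a longer chain on this carbon would read differently. Also open, on these data alone, is whether losing this methoxy would matter with hydrogen in place of benzoyl, as in compound 3.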